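The compounds below may be only part of what the source reports. "The series", "measured", "known", "first", "only" and "open" are said of these compounds alone.

Of the compounds shown here, three on a shared core have been measured in a functional assay on Caco-2 cells (Homo sapiens) for antiproliferative activity, read by MTT assay, with a stated time of 48 h; a higher number here means a weaker inhibitor, a lower number a stronger inhibitor. Compound 1 `CCn1c(C(=O)NCCN(C)C)ccc1C(CC)(CC)c1ccc(OCCC(O)(CC)CC)c(C)c1` gives 1140 nM and compound 2 `CCN(CC)CCNC(=O)c1ccc(C(CC)(CC)c2ccc(OCCC(O)(CC)CC)c(C)c2)n1CC` gives 1630 nM; a 1.4-fold higher number from compound 1 to compound 2 (0.16 log units; within the scatter). Compound 3 `CCn1c(C(=O)Nc2cccc(C(F)(F)F)c2)ccc1C(CC)(CC)c1ccc(OCCC(O)(CC)CC)c(C)c1` reaches only the limit > 50000 nM in this assay. Compound 2 thus stands highest of the two numbers, with compound 1 nearest and within the scatter. Compound 4 `CCC(C)C(NC(=O)c1ccc(C(CC)(CC)c2ccc(OCCC(O)(CC)CC)c(C)c2)n1CC)C(=O)OC` differs from compound 2 at the amide-type nitrogen: a group of 9 heavy atoms (7 carbon, 2 oxygen; no ring) in place of a group of 7 heavy atoms (6 carbon, 1 nitrogen; no ring), on an amide-type nitrogen. The measured steps that bear on this are an at least 30-fold higher number from compound 2 to compound 3 (1.48 log units; beyond the scatter) and an at least 43-fold higher number from compound 1 to compound 3 (1.64 log units; beyond the scatter), both large and both replacing the same chain on that amide-type nitrogen. A step in the same direction is expected here, a 9.2-fold higher number from compound 2 to compound 4 (0.96 log units; beyond the scatter), though smaller. Compound 4 is estimated at 15000 nM, between 4000 nM and 50000 nM in this assay.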

Compound 4, half-maximal inhibitory concentration: > 50000 nM
Compound 4 ended at the assay's limit (the forecaster's own chance of this, stated with the estimate: 35%); middle value at least 3.3-fold (0.52 log units) away from the limit.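

Loss of activity at this amide-type nitrogen does not require an aromatic ring in the entering group: the ring-free group of 9 heavy atoms gives an at least 30-fold higher number from compound 2 to compound 4 (1.48 log units; beyond the scatter) and an at least 43-fold higher number from compound 1 to compound 4 (1.64 log units; beyond the scatter). Compound 3 and compound 4 both stand at a limit rather than a number, so the step between them cannot be read: the limit of > 50000 nM in this assay, at which 2 of the 4 values shown sit.

Among the compounds shown, only compound 1 and compound 2, whose chains end in a tertiary amine, give readable numbers in this assay. As far as these compounds go, whether that amine is what separates them from compound 4 stays open; a primary amine, a carboxylic acid or a longer aminoalkyl chain at this nitrogen would bear on it.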